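The source may report more compounds than this note shows. Statements on the series, on what has been measured and on what is new or still open speak of the compounds shown alone.

Measured in an assay on CHO cells for displacement of a labelled ligand from adenosine receptor A1 (Homo sapiens), read by scintillation counting; on this read-out lower numbers stand for stronger inhibition and higher numbers for weaker inhibition:
compound 1 `Nc1nc(Cc2ccccc2Cl)nc2cn(-c3ccccc3)nc12` — 155 nM
compound 2 `Nc1nc(Cc2cccc(O)c2)nc2cn(-c3ccccc3)nc12` — 312 nM

Among the compounds with values here, compound 2 gives the highest of the two numbers so far, but its only neighbour is compound 1, and a 2.0-fold higher number from compound 1 to compound 2 (0.30 log units; within the scatter) lies within the scatter, so no order between the two compounds can be claimed. The next compound is compound 3 `Nc1nc(/C=C/c2ccccc2)nc2cn(-c3ccccc3)nc12`. Relative to compound 2 it carries 2-phenylethenyl in place of 3-hydroxybenzyl on an aromatic carbon, so the hydrogen-bond donor and acceptor of the 3-hydroxybenzyl group are gone and a 2-phenylethenyl group with its double bond outside aromatic rings takes the place. Within the data shown here, only one measured step exists, a 2.0-fold higher number from compound 1 to compound 2 (0.30 log units; within the scatter), and it concerns the exchange of one substituted phenyl for another on the benzyl carbon, not the replacement of the benzyl group itself. It bears on the present change only loosely: it shows that a change in this part of the molecule left the number within the scatter. The step is therefore expected to be about a 1.6-fold lower number from compound 2 to compound 3 (0.19 log units; within the scatter) in this assay, with no direction beyond the scatter asserted. Compound 3 is estimated at 200 nM, with a range from 50 nM to 800 nM.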

Compound 3, inhibition constant: 480 nM
Compound 3: middle estimate off by 2.4-fold (0.38 log units), on the low side; the range from low to high includes it.
By their numbers in this assay, from the lowest: compounds 1, 2 and 3 (each within the scatter of the next, the first and the last beyond it).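

In this assay, the change at this position, on the aromatic carbon between two ring nitrogen atoms, gives a 1.5-fold higher number from compound 2 to compound 3 (0.19 log units; within the scatter), so exchanging 3-hydroxybenzyl, with its hydrogen-bond donor and acceptor, for 2-phenylethenyl, with neither and with a double bond outside aromatic rings, leaves the number within the scatter. Set against the 2-chlorobenzyl group, the same 2-phenylethenyl group gives a 3.1-fold higher number from compound 1 to compound 3 (0.49 log units; beyond the scatter), the first step in the series beyond the scatter, though a modest one, and it shows that replacing the benzyl-type link can register at this position even though the middle member of the series separates from neither end. No measurement at hand speaks to the reason for either step.

On these data alone, whether this modest step belongs to the double bond or to the loss of the chloro substituent stays open, and a saturated 2-phenylethyl chain at the same carbon would separate those two readings. Also open, as far as these compounds go, is how far this position tolerates other kinds of group, such as a longer chain or a benzyl group carrying an amine or a carboxylic acid.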